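Moving from a benzyl group to a 2-nitrophenyl group

A few compounds are considered here, and "the series" means these few. Any claim that something is new, unique, unknown or untested is made for them only; others in the source may bear on it.

Of the compounds shown here, three sharing one core have been tested in a functional assay on the whole organism (strain Wistar) with Rattus norvegicus as the target, with a stated time of 15 days, at a dose of 100 mg/kg by the oral route; a lower number here means a weaker effect, a higher number a stronger effect of the compound at the dose given. Compound 1 `Cc1nc(COc2ccc(/C=C3\SC(=O)NC3=O)cc2)cs1` gives 38.9% in this assay. Compound 2 `O=C1NC(=O)/C(=C/c2ccc(OCc3csc(-c4ccccc4)n3)cc2)S1` gives 54%. Within the data shown here, the one change between those two, phenyl in place of methyl on an aromatic carbon, brought a number 15.1 percentage points higher from compound 1 to compound 2 (beyond the scatter). Compound 3 `O=C1NC(=O)/C(=C/c2ccc(OCCSc3nnc(Cc4ccccc4)[nH]3)cc2)S1` gives 41.9%; it stands second highest of the three numbers, within the scatter of compound 1 and beyond the scatter below compound 2.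

Compound 4 `O=C1NC(=O)/C(=C/c2ccc(OCCSc3nnc(-c4ccccc4[N+](=O)[O-])[nH]3)cc2)S1` has not yet been measured. It differs from compound 3 in one place: 2-nitrophenyl in place of benzyl on an aromatic carbon. Among the measured compounds shown here, no measured step changes exactly this group. For the measured compounds named here, the only step at hand is a number 15.1 percentage points higher from compound 1 to compound 2 (beyond the scatter), a modest rise on a change from methyl to phenyl, and it bears on the present change only loosely, as a weak pointer toward a small rise rather than a fall. For compound 4 the expected value in this assay is 48%, with a range from 33% to 62%. The estimated step is a number 6.1 percentage points higher from compound 3 to compound 4 (within the scatter), roughly at the edge of the scatter.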

Compound 4, a percentage reported as activity, at one dose (the size of the read-out at that dose, not a potency): 49.1%
Compound 4: middle estimate off by 1.1 percentage points, on the low side; the measured number falls inside the stated range.
By their numbers in this assay, from the lowest: compounds 1, 3, 4 and 2 (each within the scatter of the next, the first and the last beyond it).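

In this assay, putting 2-nitrophenyl in place of benzyl on this aromatic carbon, which lies between two ring nitrogen atoms, gives a number 7.2 percentage points higher from compound 3 to compound 4 (within the scatter) and so stays inside the usual variation between repeats. Among these compounds, this is the first view of this position, and it shows that these two quite different groups can occupy it without a change that can be told apart from scatter at this single dose. Nothing available explains why the read-out responds so little to this exchange.

The exchange removes the carbon link of benzyl and brings in a nitro group at the same time, and the compounds shown cannot separate these two changes. Plain phenyl on this carbon would help to separate them, while an amine or a carboxylic acid in place of the nitro group would test how much that group matters.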